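Aryl Group Variation on the Ring Nitrogen: Working Notes

The source may report more compounds than this note shows. Statements on the series, on what has been measured and on what is new or still open speak of the compounds shown alone.

compound 1 `Nc1scc(CN2CCN(c3ccc(F)cc3Cl)CC2)c1C(=O)c1ccc(Cl)cc1` — 0%
compound 2 `Nc1scc(CN2CCN(c3ccc(Cl)c(C(F)(F)F)c3)CC2)c1C(=O)c1ccc(Cl)cc1` — 3%

Both were tested in an assay on CHO cells for displacement of a labelled ligand from adenosine receptor A3 (Homo sapiens), read by scintillation counting, with a stated time of 120 min, tested at 10 uM; on this read-out lower numbers stand for less inhibition and higher numbers for more inhibition at the one concentration tested (going by the name of the read-out). Compound 1 gives 0%, the lowest of the two numbers. Its nearest neighbour, compound 2, gives 3%. Among the measured compounds shown here, the single step recorded is a number 3 percentage points higher from compound 1 to compound 2 (within the scatter).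

Compound 3 `Nc1scc(CN2CCN(c3cccc(F)c3)CC2)c1C(=O)c1ccc(Cl)cc1` is not yet measured. It differs from compound 1 by 3-fluorophenyl in place of 2-chloro-4-fluorophenyl on an amine nitrogen in a ring. For the measured compounds named here, the one step that bears on this change is the aryl exchange on the ring nitrogen, which stayed within the scatter, so for compound 3 no step beyond the scatter is expected in this assay. Compound 3 is estimated at 3%, range 0% to 15%, which means an expected a number 3 percentage points higher from compound 1 to compound 3 (within the scatter).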

Compound 3, a percentage reported as inhibition, at one concentration (the size of the read-out at that concentration, not a potency): 4%
Estimate against measurement, compound 3: 1 percentage points below; the range from low to high includes it.
By their numbers in this assay, from the lowest: compounds 1, 2 and 3 (each within the scatter of the next).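

In this assay, the 3-fluorophenyl group, which carries no chlorine, gives a number 4 percentage points higher from compound 1 to compound 3 (within the scatter) and, against the trifluoromethyl-bearing aryl group, a number 1 percentage points higher from compound 2 to compound 3 (within the scatter). Neither exchange moves the read-out beyond the scatter, so this position on the ring nitrogen now holds three differently substituted phenyl groups with no separation among them. Nothing at hand explains this. Still open, from the compounds shown here alone, is whether an amine or a carboxylic acid on this phenyl ring, or a longer chain in its place, would give a step beyond the scatter.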